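The source may report more compounds than this note shows. Statements on the series, on what has been measured and on what is new or still open speak of the compounds shown alone.

Compound 1 `COc1ccc(S(=O)(=O)N2CCc3cccc(NC(=O)C(C)(C)C)c32)cc1`: 289 nM
Compound 2 `COc1ccc(S(=O)(=O)N2CCc3cccc(NC(=O)c4cccs4)c32)cc1`: 31 nM

For the measured compounds named here, in a functional assay on MKN-45 cells (Homo sapiens) for cytotoxicity (a lower number here means a stronger inhibitor, a higher number a weaker inhibitor), compound 2 gives 31 nM, the lowest of the two numbers; its nearest neighbour is compound 1 at 289 nM, and the only measured step, a 9.3-fold lower number from compound 1 to compound 2 (0.97 log units; beyond the scatter), shows that the group on the carbonyl carbon moves the number well beyond the scatter. Compound 3 `COc1ccc(S(=O)(=O)N2CCc3cccc(NC(=O)c4ccncc4)c32)cc1` differs from compound 2 by pyridin-4-yl in place of thiophen-2-yl on a carbonyl carbon. Going by the values given here, no measured step covers an exchange of one aromatic ring for another at this position, so that step gives only a loose guide. Compound 3 is therefore expected near compound 2, with a small rise possible, a 1.9-fold higher number from compound 2 to compound 3 (0.29 log units; within the scatter). The estimated value of compound 3 is 60 nM, within 20 nM to 200 nM.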

Compound 3, half-maximal inhibitory concentration: 8.8 nM
Compound 3: middle estimate off by 6.8-fold (0.83 log units), on the high side; measured number outside the range, below it.
By their numbers in this assay, from the lowest: compound 3; then compound 2; then compound 1.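

In the exchange of one aromatic ring for another on the carbonyl carbon, the choice of ring proves to matter: pyridin-4-yl in place of thiophen-2-yl gives a further change (a 3.5-fold lower number from compound 2 to compound 3 (0.55 log units; beyond the scatter)). Against the tert-butyl amide, the same group gives the largest step in this set (a 33-fold lower number from compound 1 to compound 3 (1.52 log units; beyond the scatter)). Nothing measured here accounts for the difference between the two rings. The compounds shown leave open how a plain phenyl ring or a saturated ring amine such as piperidine on the same carbonyl carbon would compare.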